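The compounds below may be only part of what the source reports. "The series", "measured", "known", "first", "only" and "open" are said of these compounds alone.

Of the compounds shown here, two have been measured. Compound 1 `O=C(Nc1ccc([Se][Se]c2ccc(NC(=O)OCc3ccccc3)cc2)cc1)OCc1ccccc1` gives 33500 nM in a functional assay on PC-3 cells (Homo sapiens) for cytotoxicity, read by MTT assay, with a stated time of 72 h; on this read-out higher numbers stand for weaker inhibition of growth and lower numbers for stronger inhibition of growth. Compound 2 `CCCCCCOC(=O)Nc1ccc([Se]C#N)cc1` gives 44600 nM in this assay. The gap between compound 2 and compound 1 falls within the usual scatter of repeated measurements, so the two cannot be told apart on these numbers, and neither can be called weaker or stronger than the other.

Compound 3 `N#C[Se]c1ccc(NC(=O)Oc2ccccc2)cc1` shares the core of compound 2 and differs from it in one place: phenyl in place of hexyl on an oxygen next to a carbonyl group. Going by the values given here, no measured pair shows what such a swap does here, so the expectation rests on the change alone. Because compound 2 gives 44600 nM, the step from the hexyl to the phenyl is expected to stay within the scatter, with a 1.2-fold lower number from compound 2 to compound 3 (0.07 log units; within the scatter) as the estimated step and no clear direction. Compound 3 is therefore estimated at 38000 nM, with a range from 12000 nM to 110000 nM.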

Compound 3, concentration for total growth inhibition: 37500 nM
The estimate for compound 3 lay 1.0-fold (0.01 log units) above the measured number, within the range that was stated.
By their numbers in this assay, from the lowest: compounds 1, 3 and 2 (each within the scatter of the next).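

Phenyl in place of hexyl on an oxygen next to a carbonyl group gives a 1.2-fold lower number from compound 2 to compound 3 (0.08 log units; within the scatter) in this assay and is the first single change that can be read in this series. At this place, then, a chain with no ring and a six-membered aromatic ring of carbon only, each with the same count of heavy atoms, cannot be told apart on these numbers. No measurement at hand bears on why this is so.

Going by these compounds, it remains open whether any group on this oxygen can move the number beyond the scatter, for example a longer chain, a chain ending in an amine or one ending in a carboxylic acid. One pair also cannot show whether the same swap would give a similar result on another core.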